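Swapping a chlorine for a fluorine on the cinnamoyl ring

A few compounds are considered here, and "the series" means these few. Any claim that something is new, unique, unknown or untested is made for them only; others in the source may bear on it.

Compound 2 `O=C(COc1ccc(C(=O)/C=C/c2cccc(Cl)c2)cc1)N[C@H]1CCOC1=O` is tested in a functional assay on MCF7 cells (Homo sapiens) for antiproliferative activity, read by MTT assay, with a stated time of 72 h (on this read-out higher numbers stand for weaker inhibition and lower numbers for stronger inhibition), where compound 2 gives 20900 nM. Among the measured compounds shown here, this is the only number in the set: the other value, from compound 1 `O=C(COc1ccc(C(=O)/C=C/c2cccc(F)c2)cc1)N[C@H]1CCOC1=O`, is a limit of the assay, compound 1 giving > 64000 nM. The step from compound 1 to compound 2 was an at least 3.0-fold lower number from compound 1 to compound 2 (0.48 log units; beyond the scatter), so replacing the fluorine by chlorine on the aromatic ring gave a stronger inhibitor.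

Compound 3 `O=C(COc1ccc(C(=O)/C=C/c2ccc(F)cc2)cc1)N[C@H]1CCOC1=O` differs from compound 2 by 4-fluorophenyl in place of 3-chlorophenyl on a double-bonded chain carbon bound to a double-bonded chain carbon. This change both undoes the chloro-for-fluoro swap that helped compound 2 and moves the halogen on the ring. For the measured compounds named here, the measured step from compound 1 to compound 2 bears on the first part and points toward a weaker compound 3; no measured step bears on the second part. In this assay compound 3 is therefore expected to give 45000 nM, within 12000 nM to 150000 nM, an estimated step of a 2.2-fold higher number from compound 2 to compound 3 (0.33 log units; beyond the scatter).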

Compound 3, half-maximal inhibitory concentration: > 64000 nM
Compound 3 ended at the assay's limit (the forecaster's own chance of this, stated with the estimate: 40%); middle value at least 1.4-fold (0.15 log units) from the limit.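

In this assay, putting 4-fluorophenyl in place of 3-chlorophenyl on this chain carbon gives an at least 3.0-fold higher number from compound 2 to compound 3 (0.48 log units; beyond the scatter). Among the compounds shown here, compound 2, the only one of the three with chlorine, is now the only one with a readable number, while fluorine appears with no readable number in both the 3-fluorophenyl and the 4-fluorophenyl compound. Compound 1 and compound 3 each give a limit rather than a number, so the step between them cannot be read, and the effect of moving the fluorine stays hidden: the limit of > 64000 nM in this assay, at which 2 of the 3 values shown sit.

This change swaps the halogen and moves it at once, so 4-chlorophenyl would be needed to separate the two parts. Going by these compounds, whether 3-bromophenyl or 3-methoxyphenyl would match or improve on 3-chlorophenyl also remains open.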